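The source may hold more compounds than are shown below. What is called first, only, known or untested is meant among the compounds shown, and "the series" means these compounds.

Working notes on the series. Three compounds have numbers in a functional assay on DU-145 cells (Homo sapiens) for inhibition, read by trypan blue exclusion, with a stated time of 96 h (a lower number here means a stronger inhibitor of growth, a higher number a weaker inhibitor of growth), so far. Compound 1 `COc1ccc(/C=C(/SCc2ccc(F)cc2)C(=O)c2ccc(C(=O)O)cc2)cc1O` gives 10000 nM in this assay. Compound 2 `CC(=O)Nc1ccc(/C=C(/SCc2ccc(F)cc2)C(=O)c2ccc(C(=O)O)cc2)cc1[N+](=O)[O-]` gives 10000 nM in this assay, level with compound 1 at the digits recorded, and together these two hold the highest numbers of the three. Compound 3 `COc1ccccc1/C=C(/Sc1ccc(C)cc1)C(=O)c1ccc(Br)cc1` gives 9000 nM in this assay; against compound 2 the gap is within the scatter, so none of the three can be ranked against the others, and all sit at a weak level. Among the measured compounds shown here, no two measured compounds differ in a single place, so no measured step is available to lean on.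

Compound 4 `O=C(O)c1ccc(C(=O)/C(=C\c2ccc(O)c([N+](=O)[O-])c2)SCc2ccc(F)cc2)cc1` is next for this assay. It differs from compound 2 in one way: hydroxy in place of acetamido on an aromatic carbon. Nothing measured here shows what this change does, and the whole set so far clusters at one weak level, so the expected step is a 1.1-fold lower number from compound 2 to compound 4 (0.05 log units; within the scatter), nothing beyond the scatter, with the direction left open. In this assay compound 4 is estimated at about 9000 nM, with a range from 3000 nM to 30000 nM.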

Compound 4, concentration for 50% growth inhibition: > 100000 nM
Compound 4: no number, only a limit; the forecaster's own chance of this, stated with the estimate: 30%; at least 11-fold (1.04 log units) between middle value and limit.
By their numbers in this assay, from the lowest: compounds 3, 1 and 2 (each within the scatter of the next). At a limit, above all of these: compound 4.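

Compound 4 gives no number in this assay, only a limit: the limit of > 100000 nM in this assay, at which 1 of the 4 values shown sits.

Among the compounds shown here, the earlier compounds showed one flat level, whereas this aromatic carbon, ortho to a nitro group and para to a large group, proves sensitive: hydroxy in place of acetamido gives an at least 10-fold higher number from compound 2 to compound 4 (1.00 log units; beyond the scatter) and is the first step beyond the scatter. The step from the other neighbour, 4-hydroxy-3-nitrophenyl in place of 3-hydroxy-4-methoxyphenyl, gives an at least 10-fold higher number from compound 1 to compound 4 (1.00 log units; beyond the scatter) and shows that the aryl pattern of compound 4 weakens growth inhibition, although compound 1 also carries a hydroxy group on this ring; with a limit at one end, both steps give only a minimum size.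

Still open, from the compounds shown here alone, is whether the loss of the acetamido group or the arrival of the hydroxy group drives the step, and whether an amine or a methoxy group on this carbon would stay level with compound 2 or fall with compound 4. The compounds shown also leave open whether the step depends on the nitro group, since no pair here makes this change without it.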